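The source may report more compounds than this note shows. Statements on the series, on what has been measured and on what is new or still open speak of the compounds shown alone.

Of the compounds shown here, three built on a shared core have been tested in a functional assay on LoVo cells (Homo sapiens) for antiproliferative activity, read by MTT assay, with a stated time of 72 h; on this read-out lower numbers stand for stronger inhibition and higher numbers for weaker inhibition. Compound 1 `Cn1cc(-c2nn(Cc3ccc(C(=O)N4CCCCC4)cc3)c(=O)c3ccccc23)cn1` gives 77100 nM. Compound 2 `Cc1noc(C)c1-c1nn(Cc2ccc(C(=O)NC3CC(C)(C)N([O])C(C)(C)C3)cc2)c(=O)c2ccccc12` gives 41200 nM. Compound 3 `Cn1cc(-c2nn(Cc3ccc(C(=O)NC4CC4)cc3)c(=O)c3ccccc23)cn1` gives 48200 nM. The three numbers lie close together: compound 3 sits between the other two, and its gaps to compound 2 and to compound 1 both fall within the scatter of repeated measurements, so none of the three can be called stronger or weaker than another. Among the compounds with values here, the only step between compounds that differ in a single place is a 1.6-fold lower number from compound 1 to compound 3 (0.20 log units; within the scatter), an exchange at the amide nitrogen that produced no real change.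

Compound 4 `Cn1cc(-c2nn(Cc3ccc(C(=O)NC4CC(C)(C)N([O])C(C)(C)C4)cc3)c(=O)c3ccccc23)cn1` has not yet been measured. It differs from compound 3 by a group of 11 heavy atoms (9 carbon, 1 nitrogen, 1 oxygen; one six-membered non-aromatic ring with 1 hetero atom) in place of a group of 3 heavy atoms (3 carbon; one three-membered non-aromatic ring of carbon only), on an amide-type nitrogen. Within the data shown here, no measured step covers this exact exchange on this core. Two pieces of evidence bear on it. First, the one known swap at the same amide nitrogen stayed within the scatter. Second, compound 2 already carries the same entering group, on a core that differs elsewhere, and its value and that of compound 3 lie within the scatter of each other. Compound 4 is therefore expected to give about 45000 nM, with a range from 18000 nM to 110000 nM. The expected step of a 1.1-fold lower number from compound 3 to compound 4 (0.03 log units; within the scatter) amounts to none beyond the scatter.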

Compound 4, half-maximal inhibitory concentration: 50100 nM
Estimate against measurement, compound 4: 1.1-fold (0.05 log units) below; the range from low to high includes it.
By their numbers in this assay, from the lowest: compounds 2, 3, 4 and 1 (each within the scatter of the next).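

In this assay, the amide-type nitrogen of this core accepts a far bigger group with no real change: the group of 11 heavy atoms in place of cyclopropyl gives the step (a 1.0-fold higher number from compound 3 to compound 4 (0.02 log units; within the scatter)), and the same amide end in place of piperidin-1-yl on the carbonyl carbon gives the step (a 1.5-fold lower number from compound 1 to compound 4 (0.19 log units; within the scatter)). A second place can now be read as well, since 1-methyl-1H-pyrazol-4-yl in place of 3,5-dimethyl-1,2-oxazol-4-yl on an aromatic carbon gives the step (a 1.2-fold higher number from compound 2 to compound 4 (0.08 log units; within the scatter)), so among these four compounds neither place shows a change that can be told from the scatter. Nothing available explains why these exchanges leave the read-out unchanged.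

Still open, on these data alone, is whether any group at these two places can move the number beyond the scatter at all, since three kinds of amide end and two aromatic groups are a narrow sample. A chain ending in an amine or a carboxylic acid on the amide-type nitrogen, or a plain phenyl on the aromatic carbon, would test that question.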